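From methyl to hydroxymethyl: one small step in cytotoxicity

The source may hold more compounds than are shown below. What is called first, only, known or untested is meant among the compounds shown, and "the series" means these compounds.

Measured so far in an ADME assay on CHO cells (Cricetulus griseus) for cytotoxicity, read by MTT assay, with a stated time of 24 h (a lower number here means that less compound is tolerated, a higher number that more compound is tolerated), are three compounds:
compound 1 `CC1Cn2c(nc([N+](=O)[O-])c2-c2ccccc2)O1` gives > 500000 nM
compound 2 `Cc1ccc(C#Cc2c([N+](=O)[O-])nc3n2CC(C)O3)cc1` gives 5470 nM
compound 3 `COc1cccc(C#Cc2c([N+](=O)[O-])nc3n2CC(C)O3)c1` gives 12900 nM

The entry for compound 1 at > 500000 nM is a limit of the assay and not a number.

Compound 2 gives 5470 nM as the lowest of the two real numbers. The nearest is compound 3 at 12900 nM and the gap between them lies beyond the usual scatter of repeated measurements.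

Compound 4 `CC1Cn2c(nc([N+](=O)[O-])c2C#Cc2ccc(CO)cc2)O1` has not yet been measured. It is built like compound 2 with one change, counted as hydroxy in place of hydrogen on a saturated chain carbon bound to an aromatic carbon and amounting to hydroxy in place of hydrogen on a saturated chain carbon bound to an aromatic carbon. The same difference reads as methyl to hydroxymethyl.

For the measured compounds named here, no measured pair here shows this change, so its size cannot be read directly from the data. Compound 2 at 5470 nM and compound 3 at 12900 nM lie fairly close together, so a modest step toward a higher number is the expectation in this assay for now. The estimated size is a 2.2-fold higher number from compound 2 to compound 4 (0.34 log units; beyond the scatter) and this remains uncertain. For compound 4 the expected half-maximal cytotoxic concentration is 12000 nM with an estimated range from 3500 nM to 45000 nM for the coming measurement.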

Compound 4, half-maximal cytotoxic concentration: 8770 nM
Compound 4: the middle estimate sits 1.4-fold (0.14 log units) above what was measured, and the stated range covers the measured number.
By their numbers in this assay, from the lowest: compounds 2, 4 and 3 (each within the scatter of the next, the first and the last beyond it). At a limit, above all of these: compound 1.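

In this assay, for the compounds shown here, the step from methyl to hydroxymethyl can now be read directly for the first time: it is a 1.6-fold higher number from compound 2 to compound 4 (0.21 log units; within the scatter). That step lies within the usual scatter of repeated measurements, so compound 2 and compound 4 count as alike in this assay, and hydroxy in place of hydrogen on a saturated chain carbon bound to an aromatic carbon, with the hydrogen-bond donor and acceptor counted for it, leaves no difference that can be told apart from the noise of the measurement. None of the information shown bears on why these two compounds read alike.

From the compounds shown here alone, this is a single pair, so it sets no trend, and whether the same change gives an equally small step on other compounds of this kind remains open. Also open, going by these compounds, is how this assay would respond to other groups on this saturated chain carbon, such as an amine, a carboxylic acid or a longer chain ending in hydroxy, any of which could separate from compound 2 by more than the scatter or stay within it.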